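This account rests on a few compounds, and the source may have more. Where it says the series, first, only, none or still open, it means among the compounds named here.

Measured so far in a functional assay on MKN-45 cells (Homo sapiens) for cytotoxicity; on this read-out higher numbers stand for weaker inhibition and lower numbers for stronger inhibition:
- compound 1 `COc1ccc(S(=O)(=O)N2CCc3cccc(NC(=O)C(C)(C)C)c32)cc1`: 289 nM
- compound 2 `COC(=O)c1ccc(C(=O)Nc2cccc3c2N(S(=O)(=O)c2ccc(OC)cc2)CC3)cc1`: 312 nM
- compound 3 `COc1ccc(S(=O)(=O)N2CCc3cccc(NC(=O)c4ccc(C#N)cc4)c32)cc1`: 89 nM

Compound 3 has the lowest number of the three, and its gaps to both of the others lie beyond the scatter. The next compound is compound 4 `COc1ccc(S(=O)(=O)N2CCc3cccc(NC(=O)N(C)c4ccccc4)c32)cc1`, which has methyl(phenyl)amino in place of 4-cyanophenyl on a carbonyl carbon.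

For the measured compounds named here, no measured step makes this exact change, so the evidence is indirect. Two modest steps arrive at the 4-cyanophenyl group: a 3.2-fold lower number from compound 1 to compound 3 (0.51 log units; beyond the scatter) and a 3.5-fold lower number from compound 2 to compound 3 (0.54 log units; beyond the scatter). The remaining step, a 1.1-fold higher number from compound 1 to compound 2 (0.03 log units; within the scatter), stays within the scatter, so the two compounds without that group sit at one level. Compound 4 also lacks the 4-cyanophenyl group, although its new group differs from both of theirs. A modest step towards a higher number in this assay is therefore expected, similar in size to the two steps above but with wide uncertainty. The estimate means a 2.9-fold higher number from compound 3 to compound 4 (0.47 log units; beyond the scatter). Compound 4 is expected at 260 nM, with an estimated range of 90 nM to 750 nM.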

Compound 4, half-maximal inhibitory concentration: > 10000 nM
Compound 4 was reported as a limit (the forecaster's own chance of this, stated with the estimate: 3%); middle value at least 38-fold (1.58 log units) from the limit.
By their numbers in this assay, from the lowest: compound 3; then compounds 1 and 2 (each within the scatter of the next). At a limit, above all of these: compound 4.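

In this assay compound 4 gives > 10000 nM, which is a limit and not a number: the limit of > 10000 nM in this assay, at which 1 of the 4 values shown sits.

For the compounds shown here, the place on the carbonyl carbon proves far more sensitive than the earlier compounds showed: tert-butyl, 4-(methoxycarbonyl)phenyl and 4-cyanophenyl lie no more than modest steps apart, whereas methyl(phenyl)amino gives an at least 110-fold higher number from compound 3 to compound 4 (2.05 log units; beyond the scatter), an at least 32-fold higher number from compound 2 to compound 4 (1.50 log units; beyond the scatter) and an at least 34-fold higher number from compound 1 to compound 4 (1.53 log units; beyond the scatter), all large. The group that leaves and the group that enters in the step from compound 3 match in heavy atoms, in carbon and nitrogen counts and in their single six-membered aromatic ring, so these counts alone do not set the level here; they differ in the triple bond and hydrogen-bond acceptor of 4-cyanophenyl and in the nitrogen that methyl(phenyl)amino places on the carbonyl carbon.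

The compounds shown do not separate the part played by that nitrogen from the part played by its methyl, and phenylamino or benzyl at this place would bear on that question. From the compounds shown here alone, with compound 4 at a limit, the full size of its three steps also stays open.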